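Replacing a benzylic amine arm with an unsaturated oxane-bearing chain

The source may report more compounds than this note shows. Statements on the series, on what has been measured and on what is new or still open speak of the compounds shown alone.

Three compounds share one core and differ only in the arm carried on a saturated chain carbon bound to an amine nitrogen. In a functional assay on cells for antagonist activity at C-X-C chemokine receptor type 4 (Homo sapiens), read by fluorescence and calcium flux, with stated times of 25 min and 90 s (a lower number here means a stronger inhibitor, a higher number a weaker inhibitor), compound 1 `c1ccc2c(c1)CN[C@@H](CN(CCCCNCC1CCOCC1)[C@H]1CCCc3cccnc31)C2` gives 52.9 nM, compound 2 `c1ccc2c(c1)CN[C@@H](CN(CCCCNCC1CCNCC1)[C@H]1CCCc3cccnc31)C2` gives 36.5 nM, and compound 3 `NCc1ccccc1CN(C[C@H]1Cc2ccccc2CN1)[C@H]1CCCc2cccnc21` gives 50.8 nM. Compound 3 thus sits second highest of the three numbers, nearest compound 1 and furthest from compound 2, with both gaps within the scatter. Compound 4 `C(=C/CN(C[C@H]1Cc2ccccc2CN1)[C@H]1CCCc2cccnc21)\CNC1CCOCC1` arises from compound 3 by the change (3-((oxan-4-yl)amino)prop-1-en-1-yl in place of 2-(aminomethyl)phenyl on a saturated chain carbon bound to an amine nitrogen). Among the compounds with values here, the steps that bear on it are the swaps at the same position: a 1.0-fold lower number from compound 1 to compound 3 (0.02 log units; within the scatter) and a 1.4-fold higher number from compound 2 to compound 3 (0.14 log units; within the scatter), each within the scatter, as is a 1.4-fold lower number from compound 1 to compound 2 (0.16 log units; within the scatter). Since compound 4 returns to a chain-linked oxane arm resembling compound 1, which gave 52.9 nM, no step beyond the scatter is expected, and the expected change is a 1.0-fold lower number from compound 3 to compound 4 (0.01 log units; within the scatter). Compound 4 is therefore estimated at 50 nM, with a range from 20 nM to 130 nM.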

Compound 4, half-maximal inhibitory concentration: 15.5 nM
Compound 4: middle estimate off by 3.2-fold (0.51 log units), on the high side; the whole stated range lies above it.
By their numbers in this assay, from the lowest: compound 4; then compounds 2, 3 and 1 (each within the scatter of the next).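

In this assay, within the data shown here, the arm at this position moved the number beyond the scatter for the first time, with the 3-((oxan-4-yl)amino)prop-1-en-1-yl group giving a 3.3-fold lower number from compound 3 to compound 4 (0.52 log units; beyond the scatter). The same arm also separates compound 4 from the two chain-linked arms, with a 3.4-fold lower number from compound 1 to compound 4 (0.53 log units; beyond the scatter) and a 2.4-fold lower number from compound 2 to compound 4 (0.37 log units; beyond the scatter), so an oxane ring alone does not set the lower number, since compound 1 carries one as well. Nothing measured here gives a reason for this gain.

The compounds shown leave open whether the double bond or the attachment of the amine directly to the oxane ring matters more, which a saturated propyl chain bearing the same oxan-4-ylamino group would help to separate. On these data alone, it is also open whether a piperidin-4-yl group would behave like oxan-4-yl on the unsaturated chain.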